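The source may report more compounds than this note shows. Statements on the series, on what has been measured and on what is new or still open speak of the compounds shown alone.

Among the compounds with values here, in a functional assay on KG-1 cells (Homo sapiens) for cytotoxicity, read by luminescence and CellTiter-Glo, with a stated time of 3 days (on this read-out lower numbers stand for stronger inhibition and higher numbers for weaker inhibition), compound 1 (`N#Cc1ccc(NC(=O)c2cccc(Br)c2O)cc1`) gives 3260 nM, the higher of the two numbers so far. Compound 2 (`O=C(Nc1ccc(C(F)(F)F)cc1)c1cc(Br)c(F)cc1O`) gives 820 nM, which is lower by more than the scatter. Compound 3 (`N#Cc1ccc(NC(=O)c2cccc(F)c2O)cc1`) remains unmeasured. It carries fluoro in place of bromo on an aromatic carbon, ortho to a hydroxy group: fluoro in place of bromo on an aromatic carbon. Within the data shown here, no measured pair isolates this change, so the expectation in this assay is loose: a slight drift towards weaker inhibition, not beyond the scatter. The expected step is a 1.4-fold higher number from compound 1 to compound 3 (0.14 log units; within the scatter). For compound 3 the estimated value is 4500 nM, with an expected range of 1800 nM to 11000 nM.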

Compound 3, half-maximal inhibitory concentration: 9690 nM
Estimate against measurement, compound 3: 2.2-fold (0.33 log units) below, within the range that was stated.
By their numbers in this assay, from the lowest: compound 2; then compound 1; then compound 3.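

Bromo and fluoro on this aromatic carbon, ortho to a hydroxy group, are not interchangeable in this assay: the change gives a 3.0-fold higher number from compound 1 to compound 3 (0.47 log units; beyond the scatter), and this is the first pair in the series to isolate a single position. The direction favours bromo only in this one pair on the core of compound 1. Nothing measured here accounts for the step.

As far as these compounds go, how chloro, methyl or an amine would read at this position remains open. From the compounds shown here alone, whether the same step holds on the core of compound 2 is also open.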